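This account rests on a few compounds, and the source may have more. Where it says the series, first, only, none or still open, it means among the compounds named here.

Working notes on a short amide series tested in a functional assay on HO8910 cells (Homo sapiens) for inhibition, read by MTT assay, with a stated time of 24 h, tested at 1 ug/mL; a lower number here means less inhibition of growth, a higher number more inhibition of growth at the concentration tested.

Compound 1 `O=C(CCCCC1CCSS1)Nc1cccc(C(F)(F)F)c1` gives 4.76% in this assay. Compound 2 `O=C(CCCCC1CCSS1)Nc1cccc2ccccc12` carries a different aryl part on the amide nitrogen; the difference between the two cores is not broken down here. In this assay compound 2 gives 6.95%, and the two numbers lie within the scatter of each other, so no order between them is read. Compound 3 `O=C(CCCCC(S)CCS)Nc1cccc(C(F)(F)F)c1` differs from compound 1 by a group of 5 heavy atoms (3 carbon, 2 sulfur; no ring) in place of a group of 5 heavy atoms (3 carbon, 2 sulfur; one five-membered non-aromatic ring with 2 hetero atoms), on a saturated chain carbon, four bonds along the chain from a carbonyl carbon. In this assay compound 3 gives 13.7%; the step of a number 8.9 percentage points higher from compound 1 to compound 3 (within the scatter) stays within the scatter, so the change is not shown to move the read-out.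

Compound 4 `O=C(CCCCC(S)CCS)Nc1cccc2ccccc12` is not yet measured. For the measured compounds named here, it differs from compound 2 by a group of 5 heavy atoms (3 carbon, 2 sulfur; no ring) in place of a group of 5 heavy atoms (3 carbon, 2 sulfur; one five-membered non-aromatic ring with 2 hetero atoms), on a saturated chain carbon, four bonds along the chain from a carbonyl carbon, which is the same change as the one from compound 1 to compound 3, at the same place on the chain. Going by the values given here, that one example gave a number 8.9 percentage points higher from compound 1 to compound 3 (within the scatter), a step that is not distinguished from no step at all. Among the compounds with values here, the expected step of a number 6.1 percentage points higher from compound 2 to compound 4 (within the scatter) is set to a similar size, resting on the single measured step of a number 8.9 percentage points higher from compound 1 to compound 3 (within the scatter), and is held loosely, as one example within the scatter carries little weight. In this assay compound 4 is therefore expected at about 13%, with an estimated range from 2% to 26%.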

Compound 4, percent growth inhibition at one concentration: "not active" (no number reported)
For compound 4 the study gives words and no number; no gap can be computed for the estimate.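

In this assay, for the compounds shown here, compound 4 is reported in words as not active, with no number, so no step from compound 2 to compound 4 can be read. Nothing at hand bears on this result. The compounds shown leave open whether the 1,3-disulfanylpropyl group, in place of the group with the five-membered ring, moves growth inhibition at all with either aryl part.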